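The compounds below may be only part of what the source reports. "The series", "measured", "known", "first", "only" and "open" are said of these compounds alone.

Of the compounds shown here, three sharing one core have been tested in a functional assay on the whole organism (strain NMRI) with Mus musculus as the target, with a stated time of 0.5 h; on this read-out lower numbers stand for an effect already at smaller amounts and higher numbers for an effect only at larger amounts of compound. Compound 1 `O=[N+]([O-])c1ccc(Cn2cc(CO/N=C/c3c(-c4ccc(F)cc4)nc4ccc(Br)cn34)nn2)cc1` gives 40 mg/kg there. Compound 2 `COc1ccc(Cn2cc(CO/N=C/c3c(-c4ccc(F)cc4)nc4c(C)cccn34)nn2)cc1` gives 40 mg/kg in this assay, level with compound 1 at the digits shown, the two together the highest of the three numbers. Compound 3 `C#CCO/N=C/c1c(-c2ccc(C)cc2)nc2c(C)cccn12` gives 20 mg/kg in this assay, a gap from compound 2 that stays within the scatter. Compound 4 `COc1ccc(Cn2cc(CO/N=C/c3c(-c4ccccc4)nc4c(C)cccn34)nn2)cc1` has not yet been measured. It differs from compound 2 in one place: hydrogen in place of fluoro on an aromatic carbon. Within the data shown here, no measured pair differs in just this way, so no measured step guides the expectation. The step of no change at the digits printed from compound 2 to compound 4 (within the scatter) is expected to stay within the scatter. Compound 4 is therefore estimated at 40 mg/kg in this assay, with a range from 20 mg/kg to 80 mg/kg.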

Compound 4, minimum effective dose: 40 mg/kg
Compound 4: middle estimate and measured number agree at the digits printed; the range from low to high includes it.
By their numbers in this assay, from the lowest: compounds 3, 1, 2 and 4 (each within the scatter of the next).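

The first step read at this position in this assay is no change at the digits printed from compound 2 to compound 4 (within the scatter) for the change of 4-fluorophenyl to phenyl. In this one pair, then, the effect in the mice does not depend on the fluoro on this aromatic carbon. Nothing available explains this result. As far as these compounds go, what an amine, a carboxylic acid or a longer chain would do at this place stays open. So does whether the same change would leave the number as it is with the other substituents of compound 1 or compound 3.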